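A few compounds are considered here, and "the series" means these few. Any claim that something is new, unique, unknown or untested is made for them only; others in the source may bear on it.

Measured so far:
Compound 1, `Cc1nn(-c2cccc(CN)c2)c2cc(-c3ccc(N4CCCCC4=O)cc3)ccc12`, > 10000 nM.
Compound 2, `NC(=O)c1nn(-c2ccc3onc(N)c3c2)c2c(F)c(-c3ccc(N4CCCCC4=O)cc3F)ccc12`, > 10000 nM.

Both results come from an assay on isolated protein for inhibition of Trypsin (Homo sapiens); on this read-out lower numbers stand for stronger inhibition and higher numbers for weaker inhibition. For compound 1 the result of > 10000 nM is only a limit of the assay, not a number. For compound 2 the result of > 10000 nM is likewise a limit and not a number. Where compound 2 stands is therefore described only by the limit of > 10000 nM in this assay, at which 2 of the 2 values shown sit: no measured step between two compounds exists here, and the two limits together show merely that neither compound inhibits strongly enough to give a number.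

Compound 3, `CN(C)CCN(c1cccnc1)c1ccc(-c2ccc3c(C(N)=O)nn(-c4ccc5onc(N)c5c4)c3c2F)c(F)c1`, is not yet measured. The change is (2-(dimethylamino)ethyl)(pyridin-3-yl)amino in place of 2-oxopiperidin-1-yl on an aromatic carbon. Without a measured step to lean on, the size of the step can only be guessed. No step beyond the scatter is expected in this assay in either direction, because compound 2 sits at the limit of > 10000 nM in this assay, at which 2 of the 2 values shown sit, and the change gives no measured reason to expect otherwise.

Compound 3 is estimated at 15000 nM, with a range from 2000 nM to 100000 nM. The step from compound 2 to compound 3 that this estimate means is a step that the limit leaves unreadable from compound 2 to compound 3, and it is expected that the assay again reports only a limit more often than not.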

Compound 3, inhibition constant: > 10000 nM
Compound 3 ended at the assay's limit (the forecaster's own chance of this, stated with the estimate: 65%); the middle value does not contradict the limit.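

No step can be read between compound 2 and compound 3, because both results are limits of the assay and not numbers: the limit of > 10000 nM in this assay, at which 3 of the 3 values shown sit. The compounds shown leave open how strongly each one inhibits in this assay and whether replacing 2-oxopiperidin-1-yl with (2-(dimethylamino)ethyl)(pyridin-3-yl)amino changes that inhibition at all.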